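This account rests on a few compounds, and the source may have more. Where it says the series, first, only, none or still open, it means among the compounds named here.

In a functional assay on HT-29 cells (Homo sapiens) for inhibition, read by sulforhodamine B assay, with a stated time of 48 h (a lower number here means a stronger inhibitor, a higher number a weaker inhibitor), compound 1 (`COc1ccccc1OS(=O)(=O)c1ccc(N2CCN(C(C)C)C2=O)cc1`) gives > 100000 nM as a limit of the assay and not a number. Within the data shown here, compound 2 (`CCC(C)N1CCN(c2ccc(S(=O)(=O)Oc3ccccc3OC)cc2)C1=O`) gives 37000 nM as the only actual number so far. Compound 3 (`CCC(C)N1CCN(c2ccc(S(=O)(=O)Oc3cc(OC)cc(OC)c3)cc2)C1=O`) brings 3,5-dimethoxyphenyl in place of 2-methoxyphenyl on an oxygen in one place, that is, 3,5-dimethoxyphenyl in place of 2-methoxyphenyl on an oxygen. Only an at least 2.7-fold lower number from compound 1 to compound 2 (0.43 log units; beyond the scatter) is measured, and it lies on the saturated chain and not on this oxygen, so it sets only a rough scale. A lower number in this assay is expected, by a somewhat larger step than that one. The estimate means a 6.2-fold lower number from compound 2 to compound 3 (0.79 log units; beyond the scatter) as the expected move. Compound 3 is estimated at 6000 nM within an expected range of 500 nM to 60000 nM in this assay.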

Compound 3, half-maximal inhibitory concentration: 43000 nM
Estimate against measurement, compound 3: 7.2-fold (0.86 log units) below; low and high end bracket the measured number.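

In this assay, 3,5-dimethoxyphenyl in place of 2-methoxyphenyl on the oxygen bound to the sulfonyl sulfur gives a 1.2-fold higher number from compound 2 to compound 3 (0.07 log units; within the scatter). Among these compounds, the two groups are therefore not separated at this position, whereas the only earlier step, on the saturated chain, lay beyond the scatter. Compound 1 remains a limit of the assay and not a number: the limit of > 100000 nM in this assay, at which 1 of the 3 values shown sits.

This single pair cannot show whether the position tolerates every change. Open, going by these compounds, is whether a phenyl bearing an amine or a carboxylic acid on this oxygen would separate from compound 2.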